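Indole-oxazole cytotoxicity: swapping an aryl for a piperidine

The compounds below may be only part of what the source reports. "The series", "measured", "known", "first", "only" and "open" are said of these compounds alone.

Compound 1 `Fc1ccc(-c2nc(-c3c[nH]c4ccccc34)co2)cc1` and compound 2 `C(=C/c1nc(-c2c[nH]c3ccccc23)co1)\c1ccccc1` were both tested in a functional assay on MDA-MB-231 cells (Homo sapiens) for cytotoxicity, read by MTT assay, with a stated time of 48 h; on this read-out lower numbers stand for stronger inhibition and higher numbers for weaker inhibition. In this assay compound 1 gives 90400 nM, and compound 2 gives 103000 nM; the two numbers lie within the scatter of each other, so neither stands apart. Compound 3 `c1ccc2c(-c3coc(C4CCNCC4)n3)c[nH]c2c1` has not yet been measured. It differs from compound 1 by piperidin-4-yl in place of 4-fluorophenyl on an aromatic carbon. Among the compounds with values here, no measured pair shows such a change, so the step from compound 1 to compound 3 is expected to stay within the scatter, a 1.1-fold higher number from compound 1 to compound 3 (0.04 log units; within the scatter). Compound 3 is therefore estimated at 100000 nM, in a range from 30000 nM to 300000 nM.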

Compound 3, half-maximal inhibitory concentration: 528000 nM
Estimate against measurement, compound 3: 5.3-fold (0.72 log units) below; measured number above the stated range.
By their numbers in this assay, from the lowest: compounds 1 and 2 (each within the scatter of the next); then compound 3.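

In this assay, piperidin-4-yl in place of 4-fluorophenyl on this aromatic carbon gives a 5.8-fold higher number from compound 1 to compound 3 (0.77 log units; beyond the scatter) and so shows that inhibition at this position is weaker with the non-aromatic ring. Compound 1 and compound 2 did not show this, as their numbers lie within the scatter of each other.

A cyclohexyl group would be needed to tell the loss of the aromatic ring from the entry of the ring nitrogen, and a 4-aminophenyl group to test the nitrogen on an aromatic ring. No evidence at hand explains the weaker number for compound 3.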